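Compound 3: acetamido in place of bromo

The source may report more compounds than this note shows. Statements on the series, on what has been measured and on what is new or still open speak of the compounds shown alone.

Compound 1 `Cc1ccc(S(=O)(=O)N2C/C(=C\c3cccnc3)C(=O)/C(=C/c3ccccc3F)C2)cc1`: 4200 nM
Compound 2 `O=C1/C(=C/c2cccnc2)CN(S(=O)(=O)c2ccc(Br)cc2)C/C1=C\c1ccccc1F`: 8700 nM

For the measured compounds named here, in a functional assay on HepG2 cells (Homo sapiens) for cytotoxicity, read by MTT assay, with a stated time of 24 h (on this read-out lower numbers stand for stronger inhibition and higher numbers for weaker inhibition), compound 2 gives 8700 nM as the higher of the two numbers so far. Compound 3 `CC(=O)Nc1ccc(S(=O)(=O)N2C/C(=C\c3cccnc3)C(=O)/C(=C/c3ccccc3F)C2)cc1` carries acetamido in place of bromo on an aromatic carbon. Going by the values given here, one measured step bears on this change, made at the same aromatic carbon: a 2.1-fold higher number from compound 1 to compound 2 (0.32 log units; beyond the scatter), modest and just beyond the scatter. That single step involves neither an acetamido group nor any similar group, so it offers only a rough guide to size and none to direction. A modest move in this assay is therefore expected, probably not beyond the scatter, and leaning slightly towards compound 1 at 4200 nM as the only other reference point. The expected step is a 1.5-fold lower number from compound 2 to compound 3 (0.16 log units; within the scatter) as estimated here. For compound 3 the estimate is 6000 nM, with 2500 nM to 15000 nM as the expected range.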

Compound 3, half-maximal inhibitory concentration: 4560 nM
Estimate against measurement, compound 3: 1.3-fold (0.12 log units) above; the measured number falls inside the stated range.
By their numbers in this assay, from the lowest: compounds 1, 3 and 2 (each within the scatter of the next, the first and the last beyond it).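

In this assay, putting acetamido on this aromatic carbon, with the hydrogen-bond donor and acceptor that bromo lacks, gives a 1.9-fold lower number from compound 2 to compound 3 (0.28 log units; within the scatter), and replacing methyl with acetamido gives a 1.1-fold higher number from compound 1 to compound 3 (0.04 log units; within the scatter). Both steps lie within the scatter, so compound 3 cannot be ordered against either compound, even though a 2.1-fold higher number from compound 1 to compound 2 (0.32 log units; beyond the scatter) lies just beyond it; at this position, the larger acetamido group therefore stays in the same range as both methyl and bromo. No available evidence accounts for these numbers.

From the compounds shown here alone, it remains open whether an amine or a carboxylic acid on this carbon would produce a step beyond the scatter. A methylated amide or a longer acyl chain would test whether the amide hydrogen or the size of the group matters here.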